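Enlarging the Cyclic Amine on the Shared Core

A few compounds are considered here, and "the series" means these few. Any claim that something is new, unique, unknown or untested is made for them only; others in the source may bear on it.

compound 1 `O=C(c1ccccc1)N1N=C(c2cc3ccccc3oc2=O)CC1c1ccccc1`: in a functional assay on PC-3 cells (Homo sapiens) for cytotoxicity, read by MTT assay, with a stated time of 48 h (on this read-out higher numbers stand for weaker inhibition and lower numbers for stronger inhibition), compound 1 gives 5870 nM
compound 2 `CC(C)(C)NCC(=O)N1N=C(c2cc3ccccc3oc2=O)CC1c1ccccc1`: in this assay compound 2 gives 16400 nM
compound 3 `O=C(CN1CCCC1)N1N=C(c2cc3ccccc3oc2=O)CC1c1ccccc1`: in this assay compound 3 gives 50200 nM

Among these three numbers compound 3 stands highest. Its nearest neighbour is compound 2, and the step of a 3.1-fold higher number from compound 2 to compound 3 (0.49 log units; beyond the scatter) lies beyond the scatter; the step of an 8.6-fold higher number from compound 1 to compound 3 (0.93 log units; beyond the scatter) is larger still. Compound 4 `CC1CCCN(CC(=O)N2N=C(c3cc4ccccc4oc3=O)CC2c2ccccc2)C1` differs from compound 3 by 3-methylpiperidin-1-yl in place of pyrrolidin-1-yl on a saturated chain carbon bound to a carbonyl carbon. For the measured compounds named here, none of the measured steps exchanges one cyclic amine for another: the step of a 2.8-fold higher number from compound 1 to compound 2 (0.45 log units; beyond the scatter) and the step of an 8.6-fold higher number from compound 1 to compound 3 (0.93 log units; beyond the scatter) each remove the phenyl from the carbonyl carbon, and the step of a 3.1-fold higher number from compound 2 to compound 3 (0.49 log units; beyond the scatter) swaps an open amine for a ring. These steps show that the amine portion moves this assay by modest amounts, but they offer no direction for a wider ring carrying a methyl. Compound 4 is therefore expected to show a step of a 1.1-fold lower number from compound 3 to compound 4 (0.05 log units; within the scatter), which is none beyond the scatter. The estimate for compound 4 is 45000 nM, with a range from 15000 nM to 130000 nM.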

Compound 4, half-maximal inhibitory concentration: 28300 nM
For compound 4 the middle estimate is 1.6-fold (0.20 log units) above the measured one; the range from low to high includes it.
By their numbers in this assay, from the lowest: compound 1; then compounds 2, 4 and 3 (each within the scatter of the next, the first and the last beyond it).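

For the compounds shown here, with the first exchange of one cyclic amine for another on a saturated chain carbon bound to a carbonyl carbon, 3-methylpiperidin-1-yl in place of pyrrolidin-1-yl gives a 1.8-fold lower number from compound 3 to compound 4 (0.25 log units; within the scatter) in this assay, so this read-out does not tell the two rings apart. The same ring in place of (tert-butyl)amino gives a 1.7-fold higher number from compound 2 to compound 4 (0.24 log units; within the scatter), so compound 4 cannot be told apart from either neighbour, even though the step between those two amines, a 3.1-fold higher number from compound 2 to compound 3 (0.49 log units; beyond the scatter), lies beyond the scatter. In place of phenyl on a carbonyl carbon, (3-methylpiperidin-1-yl)methyl gives a 4.8-fold higher number from compound 1 to compound 4 (0.68 log units; beyond the scatter), so compound 1 with its phenyl keeps the lowest number, set apart from all three amines in this assay, and nothing measured here accounts for any of these steps.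

The compounds shown leave open how the ring size and the methyl each contribute, which a plain piperidin-1-yl on the same carbon would begin to separate. Also open, going by these compounds, is whether a morpholin-4-yl, a longer chain carrying the amine, or a pyridinyl on the carbonyl carbon would read apart from these values.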